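The source may report more compounds than this note shows. Statements on the series, on what has been measured and on what is new or still open speak of the compounds shown alone.

Three compounds have so far been measured in an assay on HEK293 cells for displacement of a labelled ligand from Type-2 angiotensin II receptor (Homo sapiens); on this read-out higher numbers stand for weaker inhibition and lower numbers for stronger inhibition:

compound 1, `CC[C@H](C)[C@H](NC(=O)c1cccc(Cn2ccnc2)c1)C(=O)Nc1nccs1`, gives 42000 nM
compound 2, `CC[C@H](C)[C@H](NC(=O)c1cccc(Cn2ccnc2)c1)C(=O)NNS(=O)(=O)c1ccccc1`, gives > 100000 nM
compound 3, `CC[C@H](C)[C@H](NC(=O)c1cccc(Cn2ccnc2)c1)C(=O)NNS(=O)(=O)c1ccc(OC)cc1`, gives 9200 nM

The value of compound 2 is a limit of the assay and not a number, as shown by the limit of > 100000 nM in this assay, at which 1 of the 3 values shown sits. Compound 2 therefore stands at the weak end of what this series shows. Among the measured compounds shown here, two measured steps touch it. Going an at least 2.3-fold higher number from compound 1 to compound 2 (0.37 log units; beyond the scatter), the number rose. Going an at least 10-fold lower number from compound 2 to compound 3 (1.03 log units; beyond the scatter), the number fell sharply.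

Compound 4, `CC[C@H](C)[C@H](NC(=O)c1cccc(Cn2ccnc2)c1)C(=O)NNC(=O)OC(C)(C)C`, is not yet measured. It differs from compound 2 by tert-butoxycarbonyl in place of phenylsulfonyl on an amine nitrogen. For the measured compounds named here, no measured step swaps the phenylsulfonyl group for something else, so neither measured step bears on it directly. The step from compound 1 to compound 2 shows that the phenylsulfonyl-bearing arm gave the weakest number seen, and the step from compound 2 to compound 3 shows that a change on that arm can move the number a great deal. The expectation is a modest move to a lower number, with wide uncertainty, so that compound 4 is estimated at 50000 nM, within 15000 nM to 150000 nM, an expected step of an at least 2.0-fold lower number from compound 2 to compound 4 (0.30 log units; that floor lies within the scatter).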

Compound 4, inhibition constant: > 100000 nM
Compound 4: only a limit was reported; the forecaster's own chance of this, stated with the estimate: 40%; middle value at least 2.0-fold (0.30 log units) from the limit.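

Compound 4 is reported only as a limit of the assay and not as a number, and compound 2 is too, so the step between them cannot be read: the limit of > 100000 nM in this assay, at which 2 of the 4 values shown sit.

What can be read lies in the other comparisons in this assay: with tert-butoxycarbonyl in place of (4-methoxyphenyl)sulfonyl on the amine nitrogen the result is an at least 10-fold higher number from compound 3 to compound 4 (1.03 log units; beyond the scatter), and with (tert-butoxycarbonyl)amino in place of 1,3-thiazol-2-yl on the amide-type nitrogen it is an at least 2.3-fold higher number from compound 1 to compound 4 (0.37 log units; beyond the scatter). A group with no ring thus joins phenylsulfonyl at the limit, so among the three groups shown on this amine nitrogen, only (4-methoxyphenyl)sulfonyl gives a measured value.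

The compounds shown do not tell whether compound 2 and compound 4 differ at all, since neither has a number that could be compared. They also leave open whether a benzoyl group or a (4-aminophenyl)sulfonyl group on this amine nitrogen would give a measured value, and so whether that value depends on the sulfonyl link, the ring or the methoxy group.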